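Cytotoxicity notes: phenyl for oxetanylmethyl on the amine

The compounds below may be only part of what the source reports. "The series", "measured", "known", "first", "only" and "open" are said of these compounds alone.

Three measured compounds share one core. Compound 1 `c1ccc(-c2nc3ccccn3c2Nc2ccc3c(c2)OCCO3)nc1` in an ADME assay on THP-1 cells (Homo sapiens) for cytotoxicity (a higher number here means that more compound is tolerated, a lower number that less compound is tolerated), gives 25600 nM. Compound 2 `Cc1ccc2nc(-c3ccc(N(C)C)cc3)c(NC3CCCCC3)n2c1` does not give a number in this assay but only a limit, > 50000 nM. Compound 3 `c1ccc(-c2nc3ccccn3c2NCC2CCO2)nc1` likewise reaches only a limit in this assay, > 50000 nM. Compound 3 therefore stands at the upper edge of what the assay reports, and it is not alone there: the limit of > 50000 nM in this assay, at which 2 of the 3 values shown sit. Among the compounds with values here, of compound 1 and compound 3 the numbers show only that compound 1 gives a value below that limit while compound 3 does not.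

Compound 4 `c1ccc(Nc2c(-c3ccccn3)nc3ccccn23)cc1` has not yet been measured. It differs from compound 3 in one place: phenyl in place of (oxetan-2-yl)methyl on a nitrogen on an aromatic ring. Within the data shown here, no measured step is available to size this change. The expectation is a small step downward in this assay, at most around the scatter, since compound 1, which also carries an aryl group on that nitrogen, gives 25600 nM. For compound 4 the step is expected as an at least 1.6-fold lower number from compound 3 to compound 4 (0.22 log units; that floor lies within the scatter). Compound 4 is thus estimated at 30000 nM, with a range from 10000 nM to 50000 nM, and a fair chance that only a limit is returned.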

Compound 4, half-maximal cytotoxic concentration: 6690 nM
For compound 4 the middle estimate is 4.5-fold (0.65 log units) above the measured one; measured number outside the range, below it.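

Within the data shown here, at this position, on a nitrogen on an aromatic ring, the group makes a clear difference in this assay: phenyl in place of (oxetan-2-yl)methyl gives an at least 7.4-fold lower number from compound 3 to compound 4 (0.87 log units; beyond the scatter) as the only measured step. On these data alone, compound 3 gives only a limit, > 50000 nM and not a number, so the step is a floor and its full size is unknown. That limit is shared within the series: the limit of > 50000 nM in this assay, at which 2 of the 4 values shown sit.

With an aryl group on this nitrogen, compound 1 gives 25600 nM and compound 4 gives 6690 nM in this assay so the presence of an aryl group does not alone fix the value.

The change swaps the oxetane ring for an aromatic ring and also removes the methyl link, and the compounds shown do not separate these two parts. A benzyl group on the same nitrogen would keep that link with an aromatic ring, while a pyridyl ring or a longer alkyl chain would test how far the value depends on the phenyl ring itself.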